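Swapping the anilide aryl group in a cyclopropane dicarboxamide series

A few compounds are considered here, and "the series" means these few. Any claim that something is new, unique, unknown or untested is made for them only; others in the source may bear on it.

Measured so far:
compound 1 `CN(C)C(=O)c1cc2cnc(Nc3ccc(NC(=O)C4(C(=O)Nc5ccc(F)cc5)CC4)cc3F)nc2n1C1CCCC1` — 6.2%
compound 2 `CN(C)C(=O)c1cc2cnc(Nc3ccc(NC(=O)C4(C(=O)Nc5ccc(Cl)c(C(F)(F)F)c5)CC4)cc3)nc2n1C1CCCC1` — 16.5%
compound 3 `CN(C)C(=O)c1cc2cnc(Nc3ccc(N)cn3)nc2n1C1CCCC1` — 3.7%

In a functional assay on HeLa cells (Homo sapiens) for inhibition, read by CCK-8 assay, with a stated time of 72 h, tested at 1 uM (on this read-out higher numbers stand for more inhibition of growth at the one concentration tested and lower numbers for less inhibition of growth), compound 2 gives 16.5%, the highest of the three numbers; compound 1 and compound 3 both stand beyond the scatter below it. Compound 4 `CN(C)C(=O)c1cc2cnc(Nc3ccc(NC(=O)C4(C(=O)Nc5ccc(F)cc5)CC4)cc3)nc2n1C1CCCC1` has not been measured. It differs from compound 2 by 4-fluorophenyl in place of 4-chloro-3-(trifluoromethyl)phenyl on an amide-type nitrogen. Compound 1, which carries the same 4-fluorophenyl on its amide nitrogen, gives only 6.2%, so compound 4 is expected to fall below compound 2. The step of a number 8.5 percentage points lower from compound 2 to compound 4 (within the scatter) is estimated as a decrease somewhat beyond the scatter. Compound 4 is expected to reach about 8%, within a range of 0% to 18%.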

Compound 4, percent growth inhibition at one concentration: 49.8%
Estimate against measurement, compound 4: 41.8 percentage points below; measured number above the stated range.
By their numbers in this assay, from the lowest: compounds 3 and 1 (each within the scatter of the next); then compound 2; then compound 4.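

In this assay, the group on the amide-type nitrogen has a large effect: 4-fluorophenyl in place of 4-chloro-3-(trifluoromethyl)phenyl raises the number (a number 33.3 percentage points higher from compound 2 to compound 4 (beyond the scatter)). The 4-fluorophenyl alone does not set the level, since hydrogen in place of fluoro on an aromatic carbon also gives a large rise (a number 43.6 percentage points higher from compound 1 to compound 4 (beyond the scatter)). No measurement at hand explains either step. From the compounds shown here alone, whether a carboxylic acid or a dimethylamino group on the phenyl at that amide-type nitrogen would keep this level stays open.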